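A few compounds are considered here, and "the series" means these few. Any claim that something is new, unique, unknown or untested is made for them only; others in the source may bear on it.

Compound 1 `O=S(=O)(NCC1COC1)c1cccc(-c2ccc3nccc(-c4ccncc4)c3n2)c1` and compound 2 `O=S(=O)(CCO)c1cccc(-c2ccc3nccc(-c4ccncc4)c3n2)c1` share one core and differ only in the group on a sulfonyl sulfur. In an ADME assay on microsomes from liver (Homo sapiens) for metabolic stability, read by LC-MS, using NADPH, with a stated time of 30 min, tested at 0.1 uM (a higher number here means that more of the compound is left, a lower number that less of the compound is left), compound 1 gives 2% and compound 2 gives 95% as the higher of the two numbers, which puts compound 2 at the top of this pair. Among the measured compounds shown here, the single measured step of a number 93 percentage points higher from compound 1 to compound 2 (beyond the scatter) is large and beyond the scatter, and it falls at the same place that changes next. Compound 3 `O=S(=O)(c1cccc(-c2ccc3nccc(-c4ccncc4)c3n2)c1)N1CCC(O)CC1` carries 4-hydroxypiperidin-1-yl in place of 2-hydroxyethyl on that sulfonyl sulfur 4-hydroxypiperidin-1-yl in place of 2-hydroxyethyl on a sulfonyl sulfur and so mixes features of both earlier compounds. Its new group contains nitrogen, as does the group of compound 1 with 2% here, yet it keeps the hydroxy group of compound 2 with 95% in the same test. One step cannot show which feature matters more, so the expectation is a fall smaller than the measured step, and the estimated change is a number 45 percentage points lower from compound 2 to compound 3 (beyond the scatter) with wide uncertainty. For compound 3 the expected value is 50% with an estimated range of 15% to 88% for now.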

Compound 3, percent of the compound remaining: 5%
Beside the measured number, compound 3's estimate is 45 percentage points above it; the whole stated range lies above it.
By their numbers in this assay, from the lowest: compounds 1 and 3 (each within the scatter of the next); then compound 2.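

Keeping the hydroxy group is not enough at this position on the sulfonyl sulfur: in this assay, the change to 4-hydroxypiperidin-1-yl gives a number 90 percentage points lower from compound 2 to compound 3 (beyond the scatter), even though both groups carry that hydroxy group. The step of a number 3 percentage points higher from compound 1 to compound 3 (within the scatter) shows that two quite different nitrogen-linked groups, one with a hydroxy group and one without, cannot be told apart in this test. Among these three compounds, the two with nitrogen attached to the sulfonyl sulfur give low numbers, and only compound 2, with its carbon chain on the sulfur, gives a high one, but nothing measured here explains this difference.

The change from compound 2 to compound 3 brings in nitrogen, a six-membered ring and a larger group all at once, so the compounds shown cannot say which of these goes with the fall. A 2-hydroxyethylamino group would place nitrogen on the sulfur without a ring, while a 4-hydroxycyclohexyl group would bring the ring without the nitrogen, and these two could begin to separate the features.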